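Aryl substituent swaps on the trifluoromethoxy-isatin core

The compounds below may be only part of what the source reports. "The series", "measured", "known", "first", "only" and "open" are said of these compounds alone.

Of the compounds shown here, three sharing the same core have been measured. Compound 1 `O=C1C(=O)N(Cc2ccc(-c3cccnc3)cc2)c2ccc(OC(F)(F)F)cc21` gives 1600 nM in a functional assay on CHO cells for positive allosteric modulation of muscarinic acetylcholine receptor M5 (Homo sapiens), read by FLIPR and calcium flux, with a stated time of 1 h; on this read-out higher numbers stand for an effect only at larger amounts of compound and lower numbers for an effect already at smaller amounts. Compound 2 `COc1cccc(Oc2ccc(CN3C(=O)C(=O)c4cc(OC(F)(F)F)ccc43)cc2)n1` gives 2200 nM in this assay, and compound 3 `O=C1C(=O)N(Cc2ccc(-c3cncnc3)cc2)c2ccc(OC(F)(F)F)cc21` gives 2100 nM. All three numbers lie within the usual scatter of one another: the step of a 1.4-fold higher number from compound 1 to compound 2 (0.14 log units; within the scatter), the step of a 1.3-fold higher number from compound 1 to compound 3 (0.12 log units; within the scatter) and the step of a 1.0-fold lower number from compound 2 to compound 3 (0.02 log units; within the scatter) are each inside it. Compound 3 therefore stands in the same band as compound 1 and compound 2, with no separation that can be read as real.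

Compound 4 `O=C1C(=O)N(Cc2ccc(Oc3ccccn3)cc2)c2ccc(OC(F)(F)F)cc21` is not yet measured. It differs from compound 3 in one place: (pyridin-2-yl)oxy in place of pyrimidin-5-yl on an aromatic carbon. The closest precedents are the step from compound 2 to compound 3, where the aryloxy substituent gave way to pyrimidin-5-yl, and the step from compound 1 to compound 2, where a directly attached pyridyl gave way to an aryloxy substituent; both stayed inside the scatter. The present change moves in the reverse sense, from a directly attached heteroaryl back to an aryloxy link, so the expected step is a 1.1-fold lower number from compound 3 to compound 4 (0.02 log units; within the scatter), i.e. none beyond the scatter. Compound 4 is expected to give about 2000 nM in this assay, within a range of 1000 nM to 4200 nM.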

Compound 4, half-maximal effective concentration: 3200 nM
Compound 4: the middle estimate sits 1.6-fold (0.20 log units) below what was measured; the measured number falls inside the stated range.
By their numbers in this assay, from the lowest: compounds 1, 3, 2 and 4 (each within the scatter of the next).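

At this aromatic carbon, para to a large group, the swap from pyrimidin-5-yl to (pyridin-2-yl)oxy gives a 1.5-fold higher number from compound 3 to compound 4 (0.18 log units; within the scatter) in this assay and the swap from pyridin-3-yl to the same group gives a 2.0-fold higher number from compound 1 to compound 4 (0.30 log units; within the scatter) so the link through oxygen has now been read against both directly attached rings without a step beyond the scatter. Hydrogen in place of methoxy on the aryloxy substituent, a change the earlier compounds did not offer, gives a 1.5-fold higher number from compound 2 to compound 4 (0.16 log units; within the scatter) and so also stays inside the scatter. No measurement on hand accounts for any of these numbers.

Every substituent here carries an aromatic ring, so the compounds shown leave open whether a saturated amine such as morpholine, a carboxylic acid or a plain alkyl chain at this carbon would give a step beyond the scatter. They also leave open whether any change at this position can reach numbers well clear of this band in this assay or whether such a shift would need a change elsewhere on the shared core.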